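Swapping the Pyridine Attachment Point and Cytotoxicity

A few compounds are considered here, and "the series" means these few. Any claim that something is new, unique, unknown or untested is made for them only; others in the source may bear on it.

Compound 1 `Clc1ccc2c(NCCNCc3ccc(-c4cccnc4)s3)ccnc2c1` and compound 3 `Clc1ccc2c(NCCNCc3ccc(-c4ccncc4)s3)ccnc2c1` differ in one part only: pyridin-4-yl in place of pyridin-3-yl on an aromatic carbon. In an ADME assay on RAW264.7 cells (Mus musculus) for cytotoxicity, read by MTT assay, with a stated time of 48 h (a higher number here means a weaker inhibitor, a lower number a stronger inhibitor), compound 1 gives 16400 nM, while compound 3 gives 6330 nM, and the step between them is a 2.6-fold lower number from compound 1 to compound 3 (0.41 log units; beyond the scatter). Compound 2 `Clc1ccc2c(NCCCNCc3ccc(-c4cccnc4)s3)ccnc2c1` carries the same pyridin-3-yl group; the difference between its core and the core of compound 1 is not broken down here. In this assay compound 2 gives 21600 nM, a number that lies within the scatter of compound 1. Compound 4 `Clc1ccc2c(NCCCNCc3ccc(-c4ccncc4)s3)ccnc2c1` has not yet been measured. It differs from compound 2 by pyridin-4-yl in place of pyridin-3-yl on an aromatic carbon, the same change that separates compound 1 from compound 3, at a place described in the same words. Among the compounds with values here, only one measured pair shows this change, so any expectation rests on that pair alone. For compound 4 in this assay a step of a 2.6-fold lower number from compound 2 to compound 4 (0.42 log units; beyond the scatter) is expected, because the measured pair shows a 2.6-fold lower number from compound 1 to compound 3 (0.41 log units; beyond the scatter). Compound 4 is therefore estimated at 8300 nM, with a likely range from 4000 nM to 18000 nM.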

Compound 4, half-maximal inhibitory concentration: 3320 nM
Beside the measured number, compound 4's estimate is 2.5-fold (0.40 log units) above it; measured number outside the range, below it.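

The change from pyridin-3-yl to pyridin-4-yl lowers the number on the second core too, with a 6.5-fold lower number from compound 2 to compound 4 (0.81 log units; beyond the scatter). In this assay the change points the same way on both cores, and the two steps lie close enough to count as one effect, not two different ones: the same change on two cores in this assay, a 2.6-fold lower number (0.41 log units; beyond the scatter) from compound 1 to compound 3 and a 6.5-fold lower number (0.81 log units; beyond the scatter) from compound 2 to compound 4, 2.5-fold (0.40 log units) apart, within the scatter of two such steps. So in this small series the change carried from one core to the other in direction and, as far as two pairs can tell, in size, but two pairs cannot show why it lowers the number or that it would do so on any further core.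

The compounds shown leave open where pyridin-2-yl, or a plain phenyl ring with no ring nitrogen, would fall in this assay at the same place on the ring with the sulfur. They also leave open whether the step would hold with a longer chain in the core.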